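From a Nitro Group to a Bromo Group: Compound 4

The source may report more compounds than this note shows. Statements on the series, on what has been measured and on what is new or still open speak of the compounds shown alone.

Compound 1 `O=C(/C=C/c1ccc([N+](=O)[O-])cc1)c1ccc[nH]1` gives 14000 nM in a functional assay on HL-60 cells (Homo sapiens) for inhibition, read by MTT assay, with a stated time of 48 h; a lower number here means a stronger inhibitor, a higher number a weaker inhibitor.
Compound 2 `O=C(/C=C/c1cccc([N+](=O)[O-])c1)c1ccc[nH]1` gives 20000 nM in this assay.
Compound 3 `COc1cccc(/C=C/C(=O)c2ccc[nH]2)c1` gives 16000 nM in this assay.

Compound 1 has the lowest of the three numbers, yet its gaps to compound 3 and to compound 2 both lie within the scatter, so the three compounds stand on one level and none can be set above another. Going by the values given here, the single one-place step among the measured compounds, a 1.3-fold lower number from compound 2 to compound 3 (0.10 log units; within the scatter), also stays within the scatter.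

Compound 4 `O=C(/C=C/c1ccc(Br)cc1)c1ccc[nH]1` differs from compound 1 in one place: bromo in place of nitro on an aromatic carbon. Among the compounds with values here, no measured pair exchanges nitro for bromo, so the only step that bears on this change is the exchange of nitro for methoxy on an aromatic carbon between compound 2 and compound 3, which did not move the number beyond the scatter. Because a 1.3-fold lower number from compound 2 to compound 3 (0.10 log units; within the scatter) was that small and the three measured numbers sit so close together, the expectation for compound 4 in this assay is no step beyond the scatter in either direction. Compound 4 is therefore estimated at 16000 nM, with a range from 7000 nM to 36000 nM. This estimate means an expected step of a 1.1-fold higher number from compound 1 to compound 4 (0.06 log units; within the scatter).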

Compound 4, half-maximal inhibitory concentration: 32000 nM
For compound 4 the middle estimate is 2.0-fold (0.30 log units) below the measured one, and the stated range covers the measured number.
By their numbers in this assay, from the lowest: compounds 1, 3, 2 and 4 (each within the scatter of the next, the first and the last beyond it).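

In this assay, going by these compounds alone, the exchange of nitro for bromo on an aromatic carbon, para to a group of 9 heavy atoms, gives a 2.3-fold higher number from compound 1 to compound 4 (0.36 log units; beyond the scatter) and so becomes the first one-place step here to pass beyond the scatter, though only modestly. The earlier exchange of nitro for methoxy, a 1.3-fold lower number from compound 2 to compound 3 (0.10 log units; within the scatter) as its result, had stayed within the scatter, but that pair carries its groups at a different place on the ring, so the two steps do not describe one position. At this position, then, the number does respond to the group placed there, and it rises when the three heavy atoms of nitro give way to the single atom of bromo, though nothing measured here explains why.

A single pair cannot show whether the rise follows from the arrival of bromo or from the departure of nitro, and it gives no trend across groups at this position. Going by these compounds, how an amine, a carboxylic acid or a chloro group at this same place would compare with nitro and bromo remains open, as does whether any group here could bring the number below that of compound 1.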